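The compounds below may be only part of what the source reports. "The series", "measured", "known", "first", "only" and "open" are said of these compounds alone.

Measured compounds:
compound 1 `O=C(Nc1cccc(-c2oc3cc(-c4ccc(F)cc4)ccc3c(=O)c2O)c1)c1ccccc1F` — 5630 nM
compound 2 `O=C(Nc1cccc(-c2oc3cc(-c4ccc(F)cc4)ccc3c(=O)c2O)c1)c1ccc(F)cc1F` — 10700 nM
compound 3 `Cc1cccc(C(=O)Nc2cccc(-c3oc4cc(-c5ccc(F)cc5)ccc4c(=O)c3O)c2)c1` — 6650 nM

All three share one core and differ only in the aryl on the carbonyl carbon of the amide. In a functional assay on HeLa cells (Homo sapiens) for antiproliferative activity, read by CCK-8 assay, with a stated time of 72 h (a lower number here means a stronger inhibitor, a higher number a weaker inhibitor), compound 2 gives the largest number of the three, but the step of a 1.9-fold higher number from compound 1 to compound 2 (0.28 log units; within the scatter) and the step of a 1.6-fold lower number from compound 2 to compound 3 (0.21 log units; within the scatter) both fall within the scatter, so the three compounds cannot be separated on these numbers.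

Compound 4 `Cc1cc(C)cc(C(=O)Nc2cccc(-c3oc4cc(-c5ccc(F)cc5)ccc4c(=O)c3O)c2)c1` is not yet measured. It differs from compound 2 in one place: 3,5-dimethylphenyl in place of 2,4-difluorophenyl on a carbonyl carbon

Among the compounds with values here, two measured steps bear on this change. Replacing a fluorinated aryl with a methylated one, a 1.2-fold higher number from compound 1 to compound 3 (0.07 log units; within the scatter) and a 1.6-fold lower number from compound 2 to compound 3 (0.21 log units; within the scatter), moved the number little in either case. Exchanging 2,4-difluorophenyl for 3,5-dimethylphenyl is expected to behave in the same way, with no step beyond the scatter in this assay, if anything a slightly lower number as seen for compound 3. The estimate for compound 4 is therefore 6500 nM, with a range of 2800 nM to 15000 nM, which corresponds to an expected step of a 1.6-fold lower number from compound 2 to compound 4 (0.22 log units; within the scatter).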

Compound 4, half-maximal inhibitory concentration: 5540 nM
Beside the measured number, compound 4's estimate is 1.2-fold (0.07 log units) above it; the range from low to high includes it.
By their numbers in this assay, from the lowest: compounds 4, 1, 3 and 2 (each within the scatter of the next).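

In this assay, methyl in place of hydrogen on the aromatic ring of the amide aryl gives a step that stays within the scatter (a 1.2-fold lower number from compound 3 to compound 4 (0.08 log units; within the scatter)). Setting 3,5-dimethylphenyl against the fluorinated aryls on the carbonyl carbon also stays within the scatter (a 1.9-fold lower number from compound 2 to compound 4 (0.29 log units; within the scatter); a 1.0-fold lower number from compound 1 to compound 4 (0.01 log units; within the scatter)), so adding a second methyl separates none of the four compounds, and the position carries fluoro or methyl groups with no readable difference. No measured evidence accounts for this flat picture.

Open, going by these compounds, is whether any group on this aryl moves the number beyond the scatter, since only fluoro and methyl appear here. An amine or a carboxylic acid on the ring, or a longer chain in place of the aryl, could still separate from these four.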